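A few compounds are considered here, and "the series" means these few. Any claim that something is new, unique, unknown or untested is made for them only; others in the source may bear on it.

Compound 1 `Nc1cccc(-c2cccc(NC(=O)C(Cl)Cl)c2)c1`: 26100 nM
Compound 2 `CCOc1ccccc1-c1cc(NC(=O)C(Cl)Cl)cc(-c2ccccc2OCC)c1`: 8730 nM

Both values come from a functional assay on KB 3-1 cells (Homo sapiens) for cytotoxicity, read by MTT assay, with a stated time of 68 h; a higher number here means a weaker inhibitor, a lower number a stronger inhibitor. Compound 1 has the higher of the two numbers and is therefore the weaker inhibitor, and compound 2 lies below it by more than the usual scatter. Compound 3 `COc1cccc(-c2cccc(NC(=O)C(Cl)Cl)c2)c1` has not yet been measured. It keeps the core of compound 1 and differs from it in one place: methoxy in place of amino on an aromatic carbon. In words, methoxy stands in place of amino on an aromatic carbon, meta to a large group. For the measured compounds named here, no measured pair of compounds shows this change or any other single change, so the expectation rests on little. Going by the values given here, compound 2, at 8730 nM, shows only that a number lower than that of compound 1 is reachable with this amide. A small step towards a lower number in this assay is therefore expected, one that may not clear the scatter: a 1.7-fold lower number from compound 1 to compound 3 (0.24 log units; within the scatter). For compound 3 the estimated value is 15000 nM, with an expected range from 5500 nM to 40000 nM.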

Compound 3, half-maximal inhibitory concentration: 43300 nM
The estimate for compound 3 lay 2.9-fold (0.46 log units) below the measured number; measured number above the stated range.
By their numbers in this assay, from the lowest: compound 2; then compounds 1 and 3 (each within the scatter of the next).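

In this assay, methoxy in place of amino on an aromatic carbon, meta to a large group, gives a 1.7-fold higher number from compound 1 to compound 3 (0.22 log units; within the scatter), so this single change does not separate the two compounds. For the compounds shown here, this is the first single change that can be read at this position: the step goes from 1 hydrogen-bond donor to 0 hydrogen-bond donors, with 1 hydrogen-bond acceptor on each side and one more heavy atom, and the number stays within the scatter. No measurement is available that explains this result or bears on it.

The compounds shown leave open whether a different kind of group at this position, such as a carboxylic acid, a dimethylamino group or a longer chain such as butoxy, would give a step that clears the scatter. They also leave open whether the exchange of amino for methoxy would give a similar step at another carbon of the same ring, or with another amide on the shared core.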